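This account rests on a few compounds, and the source may have more. Where it says the series, first, only, none or still open, it means among the compounds named here.

Among the compounds with values here, the three compounds measured so far share one core and differ only in the groups on the aromatic ring. Compound 1 `CC(C)c1ccc(C(=O)/C=C/C(=O)O)c(C(C)C)c1` carries two isopropyl groups; in a functional assay on LS174T cells (Homo sapiens) for inhibition, read by MTT assay, with a stated time of 72 h (a higher number here means a weaker inhibitor, a lower number a stronger inhibitor), compound 1 gives 5360 nM. Compound 2 `O=C(O)/C=C/C(=O)c1cc(C2CCCCC2)ccc1C1CCCCC1` carries two cyclohexyl groups, and in this assay compound 2 gives 4280 nM, which lies within the scatter of the value of compound 1. Compound 3 `Cc1ccc(C)c(C(=O)/C=C/C(=O)O)c1` carries two methyl groups, and in this assay compound 3 gives 22000 nM, the highest of the three numbers and beyond the scatter from compound 1. Among the three, compound 1 thus stands second highest, close to compound 2 and well apart from compound 3.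

Compound 4 `CC(C)c1ccc(C(=O)/C=C/C(=O)O)cc1` has not yet been measured. It differs from compound 1 in one place: hydrogen in place of isopropyl on an aromatic carbon. Within the data shown here, no measured pair shows this change directly, so its size is only estimated. Since compound 3, with the smallest groups, has the highest number, the loss of one isopropyl group is expected to raise the number moderately; the step from compound 1 to compound 4 is estimated at a 2.2-fold higher number from compound 1 to compound 4 (0.35 log units; beyond the scatter). Compound 4 is therefore expected to give about 12000 nM in this assay, with a likely range from 5000 nM to 30000 nM.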

Compound 4, half-maximal inhibitory concentration: 25700 nM
Compound 4: middle estimate off by 2.1-fold (0.33 log units), on the low side; measured number inside the range.
By their numbers in this assay, from the lowest: compounds 2 and 1 (each within the scatter of the next); then compounds 3 and 4 (each within the scatter of the next).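

In this assay, hydrogen in place of isopropyl on an aromatic carbon, ortho to a group of 7 heavy atoms, gives a 4.8-fold higher number from compound 1 to compound 4 (0.68 log units; beyond the scatter). Within the data shown here, this is the first step that isolates a single place: the earlier compounds differed from one another at both ring substituents, so none could show what one isopropyl group contributes on its own. With the isopropyl group meta to this position left unchanged, the step shows that the group at this position matters in this assay, although no measurement bears on the reason for the shift.

Going by these compounds, what a methyl group, a methoxy group or a chlorine atom would do at this same position stays open, so it cannot yet be said whether the number follows the group placed there or simply depends on having any carbon group rather than hydrogen. Also open, on these data alone, are the result of removing the other isopropyl group while keeping this one, and that of an amide in place of the carboxylic acid on the shared core.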